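Chloro to methoxy: working notes on compound 3

A few compounds are considered here, and "the series" means these few. Any claim that something is new, unique, unknown or untested is made for them only; others in the source may bear on it.

In a functional assay on HCT-116 cells (Homo sapiens) for antiproliferative activity, read by MTT assay, with a stated time of 72 h (a higher number here means a weaker inhibitor, a lower number a stronger inhibitor), compound 1 `C#Cc1cccc(NC(=O)CCc2cccc3c2B(O)OC3)c1` gives 3600 nM and compound 2 `O=C(CCc1cccc2c1B(O)OC2)Nc1cccc(-c2ccc(Cl)cc2)c1` gives 380 nM as the lowest of the two numbers. For the measured compounds named here, the one measured step, a 9.5-fold lower number from compound 1 to compound 2 (0.98 log units; beyond the scatter) with 4-chlorophenyl in place of ethynyl on an aromatic carbon, bears only indirectly on compound 3 `COc1ccc(-c2cccc(NC(=O)CCc3cccc4c3B(O)OC4)c2)cc1` where methoxy in place of chloro on an aromatic carbon means methoxy in place of chloro on an aromatic carbon, para to a large group. Going by the values given here, no measured pair tests this swap, so no step beyond the scatter is expected. The expected change is a 1.2-fold higher number from compound 2 to compound 3 (0.07 log units; within the scatter) leaning towards a slightly higher number. Compound 3 is estimated at 450 nM with an expected range from 200 nM to 1000 nM for this measurement.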

Compound 3, half-maximal inhibitory concentration: 160 nM
Beside the measured number, compound 3's estimate is 2.8-fold (0.45 log units) above it; measured number below the stated range.
By their numbers in this assay, from the lowest: compound 3; then compound 2; then compound 1.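

In this assay, methoxy in place of chloro on the aromatic carbon para to a large group gives a 2.4-fold lower number from compound 2 to compound 3 (0.38 log units; beyond the scatter) and so shows that this position is sensitive to the group it carries. Replacing ethynyl with 4-methoxyphenyl gives a 23-fold lower number from compound 1 to compound 3 (1.35 log units; beyond the scatter) and makes compound 3 the lowest of the three numbers. Nothing available explains the difference between methoxy and chloro.

The compounds shown leave open how an amine, a hydroxyl group or a longer ethoxy chain would read at this position. They also leave open whether the same order holds in other cell lines.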